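This account rests on a few compounds, and the source may have more. Where it says the series, first, only, none or still open, it means among the compounds named here.

Measured so far in a functional assay on U-937 cells (Homo sapiens) for cytotoxicity, read by MTT assay, with a stated time of 48 h; on this read-out lower numbers stand for stronger inhibition and higher numbers for weaker inhibition:

compound 1, `S=C(Nc1ccccc1)Nc1nc2c(Cl)cccc2s1`: > 50000 nM.
compound 2, `c1ccc2sc(Nc3nc4ccccc4s3)nc2c1`: 40000 nM.

Compound 1 gives > 50000 nM, which is a limit of the assay and not a number. Compound 2 gives 40000 nM in this assay. Going by the values given here, the two compounds do not differ in one place only, so no step between them is counted, and the pair shows no more than what its two values show: a number for compound 2 and a limit for compound 1. Compound 1 thus stands at the limit of > 50000 nM in this assay, at which 1 of the 2 values shown sits, and its position on the scale is known only as that limit.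

Compound 3, `Fc1ccc(NC(=S)Nc2nc3c(Cl)cccc3s2)cc1`, has not yet been measured in this assay. It differs from compound 1 by fluoro in place of hydrogen on an aromatic carbon.

Among the compounds with values here, no measured step of this kind is at hand. The change is small, and the step that the limit leaves unreadable from compound 1 to compound 3 is expected to stay within the usual scatter rather than move compound 3 off the limit in either direction. Compound 3 is therefore estimated at 60000 nM in this assay. Its expected range runs from 25000 nM to 150000 nM. A limit rather than a number is expected to be the more likely report for compound 3.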

Compound 3, half-maximal inhibitory concentration: > 50000 nM
Compound 3: no number, only a limit (the forecaster's own chance of this, stated with the estimate: 75%); the middle value does not contradict the limit.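

No step can be read from compound 1 to compound 3, since both give only a limit and not a number in this assay. The compounds shown leave open where compound 1 and compound 3 actually lie on the scale, and what fluoro in place of hydrogen does where both values are numbers.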